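Chain methyl across two alkyne cores

This account rests on a few compounds, and the source may have more. Where it says the series, first, only, none or still open, it means among the compounds named here.

Compound 2 `CC(=O)N(C)CC#CCn1ccnc1` and compound 1 `CC(=O)N(C)C(C)C#CCn1ccnc1` share one core and differ in a single place, (methyl in place of hydrogen on a saturated chain carbon bound to an amide-type nitrogen and a triple-bonded carbon). In a functional assay on the whole organism for antagonist activity, with Mus musculus as the target (on this read-out lower numbers stand for an effect already at smaller amounts and higher numbers for an effect only at larger amounts of compound), compound 2 gives > 100 mg/kg, which is a limit of the assay and not a number. In this assay compound 1 gives > 100 mg/kg, again a limit of the assay rather than a number. The step that the two limits leave unreadable from compound 2 to compound 1 is therefore unreadable in size, because both values sit at the limit of > 100 mg/kg in this assay, at which 2 of the 3 values shown sit.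

Compound 3 `COC(=O)N(C)CC#CCN1CCCC1` carries the other core of the series; the difference between the two cores is not broken down here. In this assay compound 3 gives > 10 mg/kg, a limit of the assay and not a number, since it sits at the limit of > 10 mg/kg in this assay, at which 1 of the 3 values shown sits.

Compound 4 `COC(=O)N(C)C(C)C#CCN1CCCC1` has not yet been measured in this assay. It stands to compound 3 as compound 1 stands to compound 2, the change being (methyl in place of hydrogen on a saturated chain carbon bound to an amide-type nitrogen and a triple-bonded carbon); the place of the change is the same in both pairs, so this is the same change made on a second core. Among the measured compounds shown here, no measured step gives its size, so no shift is expected in either direction: the step from compound 3 to compound 4 is estimated at a step that the limit leaves unreadable from compound 3 to compound 4, resting on compound 3 giving > 10 mg/kg and on the step that the two limits leave unreadable from compound 2 to compound 1 being unreadable. Compound 4 is expected to give 30 mg/kg in this assay, with an estimated range from 8 mg/kg to 150 mg/kg, and a second limit rather than a number is the likelier outcome.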

Compound 4, dose for half-maximal effect: > 100 mg/kg
Compound 4: a limit, no number; the forecaster's own chance of this, stated with the estimate: 70%; middle value at least 3.3-fold (0.52 log units) away from the limit.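

Among the compounds shown here, no step from compound 3 to compound 4 can be read in this assay, as both values are limits and not numbers. The compounds shown leave open whether methyl in place of hydrogen at this place on the chain changes the dose for half-maximal effect at all, in either direction, on either core: none of the four gives a number.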